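Adding an Ethynyl Group to a Hydrazone Scaffold

The source may report more compounds than this note shows. Statements on the series, on what has been measured and on what is new or still open speak of the compounds shown alone.

Of the compounds shown here, two have so far been tested in an assay on isolated protein for binding affinity to corticotropin-releasing factor receptor 1 (Homo sapiens); on this read-out higher numbers stand for weaker inhibition and lower numbers for stronger inhibition. Compound 1, `CC(=O)/C(=N\Nc1ccccc1C(F)(F)F)N(C)c1cccc(Cl)c1`, did not yield a number: in this assay compound 1 gives > 10000 nM, which is a limit of the test rather than a measurement, namely (the limit of > 10000 nM in this assay, at which 1 of the 2 values shown sits). Within the data shown here, compound 2, `CC(=O)/C(=N\c1ccccc1)NNc1ccccc1C`, is the only compound with an actual number: in this assay compound 2 gives 526 nM. Among the measured compounds shown here, compound 2 therefore stands as the sole measured point in this set, and no pair of compounds differing in a single place has been measured, so there is no measured step to guide a forecast.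

Compound 3, `C#Cc1cccc(/N=C(/NNc2ccccc2C)C(C)=O)c1`, is still unmeasured. It differs from compound 2 by ethynyl in place of hydrogen on an aromatic carbon. For the measured compounds named here, with no measured step available, only a modest shift is expected, and in this assay the change is estimated at a 1.8-fold lower number from compound 2 to compound 3 (0.24 log units; within the scatter). For compound 3 the expected value in this assay is 300 nM, within a range from 80 nM to 1500 nM.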

Compound 3, inhibition constant: 62 nM
The estimate for compound 3 lay 4.8-fold (0.68 log units) above the measured number; measured number below the stated range.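

In this assay, ethynyl in place of hydrogen on an aromatic carbon, meta to a large group, gives an 8.5-fold lower number from compound 2 to compound 3 (0.93 log units; beyond the scatter). Among these compounds, this is the first measured step in the set, and it shows that this carbon of the ring is a place where a small addition can move the number beyond the usual scatter: the entering group has only 2 heavy atoms, no ring, no hydrogen-bond donors or acceptors and no net charge. The measurements shown say nothing about why this addition lowers the number.

A single step cannot tell whether the drop belongs to ethynyl itself or whether other groups on the same carbon, such as a nitrile, a methoxy group, a chlorine atom or a longer chain ending in a triple bond, would lower the number as well. Going by these compounds, it also remains open whether ethynyl would give a similar step on another carbon of that ring, or on a compound that differs from compound 2 elsewhere in the core.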